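Acyl variation on the piperidine nitrogen, compound 4 pending

The source may hold more compounds than are shown below. What is called first, only, known or untested is meant among the compounds shown, and "the series" means these compounds.

Measured so far in a functional assay on isolated protein for inhibition of Glucose-dependent insulinotropic receptor (Rattus norvegicus), read by HTRF and cAMP accumulation; a lower number here means that less compound is needed, a higher number that more compound is needed for the effect:
compound 1 `Cc1nc(S(C)(=O)=O)ccc1Oc1ncnc(OC2CCN(C(=O)OC3COC3)CC2)c1F`, 2500 nM
compound 2 `Cc1nc(S(C)(=O)=O)ccc1Oc1ncnc(OC2CCN(C(=O)SC(C)(C)C)CC2)c1F`, 30.7 nM
compound 3 `Cc1nc(S(C)(=O)=O)ccc1Oc1ncnc(OC2CCN(C(=O)C3CCCC3)CC2)c1F`, 407 nM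

Compound 3 stands second highest of the three numbers in this assay, nearer compound 1 than compound 2: the step of a 6.1-fold lower number from compound 1 to compound 3 (0.79 log units; beyond the scatter) is modest, while a 13-fold higher number from compound 2 to compound 3 (1.12 log units; beyond the scatter) is large. All three differ only in the group on the carbonyl carbon, so every recorded step bears on the next change.

Compound 4 `Cc1nc(S(C)(=O)=O)ccc1Oc1ncnc(OC2CCN(C(=O)c3noc(C(C)C)n3)CC2)c1F` carries 5-isopropyl-1,2,4-oxadiazol-3-yl in place of cyclopentyl on a carbonyl carbon. Among the measured compounds shown here, no measured pair brings an aromatic or heteroatom-containing ring into this position, so the direction must be read from the spread of the three known values. The spread is wide, from compound 1 to compound 2, and compound 3 sits within it; a change of this size could move the number either way. An expected step of a 2.0-fold lower number from compound 3 to compound 4 (0.31 log units; beyond the scatter) is taken, a modest lowering, with wide uncertainty. Compound 4 is therefore estimated at 200 nM in this assay, in a range of 40 nM to 1000 nM.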

Compound 4, half-maximal effective concentration: 176 nM
Compound 4: the middle estimate sits 1.1-fold (0.06 log units) above what was measured, and the stated range covers the measured number.
By their numbers in this assay, from the lowest: compound 2; then compound 4; then compound 3; then compound 1.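

In this assay, an aromatic ring with hetero atoms is accepted on the carbonyl carbon: 5-isopropyl-1,2,4-oxadiazol-3-yl gives a lower number than cyclopentyl (a 2.3-fold lower number from compound 3 to compound 4 (0.36 log units; beyond the scatter)). It still falls short of (tert-butyl)sulfanyl (a 5.7-fold higher number from compound 2 to compound 4 (0.76 log units; beyond the scatter)) but lies well clear of (oxetan-3-yl)oxy (a 14-fold lower number from compound 1 to compound 4 (1.15 log units; beyond the scatter)), so the two groups joined through carbon, in compound 3 and compound 4, both sit between the oxygen-linked compound 1 and the sulfur-linked compound 2. No measurement at hand accounts for any of these steps.

The compounds shown leave open whether the lowering comes from the oxadiazole ring or from its isopropyl group, which a phenyl ring or a methyl in place of isopropyl would address. They also leave open how much of the low number of compound 2 belongs to sulfur rather than to the tert-butyl group, a question for tert-butoxy on the same carbonyl carbon.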